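A few compounds are considered here, and "the series" means these few. Any claim that something is new, unique, unknown or untested is made for them only; others in the source may bear on it.

Compound 1 `CCO/C(O)=C1\C(COCCNC(=O)c2cnccn2)=NC(C)=C(C(=O)OC)C1c1ccccc1Cl` gives 39.8 nM in a functional assay (aorta) with Rattus norvegicus as the target; a higher number here means a weaker inhibitor, a lower number a stronger inhibitor.
Compound 2 `CCO/C(O)=C1\C(COCCNC(=O)NC)=NC(C)=C(C(=O)OC)C1c1ccccc1Cl` gives 3.16 nM.
Compound 3 `CCO/C(O)=C1\C(COCCN(C)S(N)(=O)=O)=NC(C)=C(C(=O)OC)C1c1ccccc1Cl` gives 25.1 nM.

Among these three numbers compound 3 stands second highest: the step of a 1.6-fold lower number from compound 1 to compound 3 (0.20 log units; within the scatter) leaves it and compound 1 indistinguishable, while the step of a 7.9-fold higher number from compound 2 to compound 3 (0.90 log units; beyond the scatter) sets it clearly apart from compound 2. Compound 4 `CCO/C(O)=C1\C(COCCNC(C)(C)C(N)=O)=NC(C)=C(C(=O)OC)C1c1ccccc1Cl` differs from compound 3 by (1-carbamoyl-1-methylethyl)amino in place of methyl(sulfamoyl)amino on a saturated chain carbon, two bonds along the chain from an oxygen on a saturated carbon. Among the compounds with values here, no measured step carries the entering group; the two steps at this chain end, a 13-fold lower number from compound 1 to compound 2 (1.10 log units; beyond the scatter) and a 7.9-fold higher number from compound 2 to compound 3 (0.90 log units; beyond the scatter), show only that changes here can move the number well beyond the scatter in either direction. With no closer guide, compound 4 is expected to land between the measured extremes, a step of a 1.7-fold lower number from compound 3 to compound 4 (0.22 log units; within the scatter). The value of compound 4 is estimated at 15 nM, with a range from 4 nM to 60 nM.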

Compound 4, half-maximal inhibitory concentration: 3.16 nM
For compound 4 the middle estimate is 4.7-fold (0.68 log units) above the measured one, outside the stated range (below it).
By their numbers in this assay, from the lowest: compounds 2 and 4 (each within the scatter of the next); then compounds 3 and 1 (each within the scatter of the next).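

In this assay, within the data shown here, the methylcarbamoyl of compound 2 proves not to be the only group on this amine nitrogen that reaches the low end of the series: 1-carbamoyl-1-methylethyl, a group with a saturated carbon on the nitrogen, shows no change at the digits printed from compound 2 to compound 4 (within the scatter). The same change of chain end also separates it from the other two, with a 7.9-fold lower number from compound 3 to compound 4 (0.90 log units; beyond the scatter) and a 13-fold lower number from compound 1 to compound 4 (1.10 log units; beyond the scatter). No evidence on why these numbers fall as they do is available. From the compounds shown here alone, it remains open whether the carbamoyl or the two methyl groups matter more, and what a carboxylic acid in place of that carbamoyl or a longer chain would give.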